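The source may hold more compounds than are shown below. What is called first, only, known or untested is meant among the compounds shown, and "the series" means these compounds.

Measured in an ADME assay on HEK-293T cells (Homo sapiens) for cytotoxicity, read by luminescence and CellTiter-Glo, with a stated time of 24 h; a lower number here means that less compound is tolerated, a higher number that more compound is tolerated:
- Compound 1 `CCCNC(=O)C1CCN(C(=O)c2cc3sc(-c4ccccc4)nc3n2Cc2ccc(OC)cc2)CC1`: 22900 nM
- Compound 2 `CCCNC(=O)C1CCN(C(=O)c2cc3ccccc3n2Cc2ccc(OC)cc2)CC1`: 26000 nM
- Compound 3 `CCCNC(=O)[C@@H]1C[C@H]2CCC[C@@H](C1)[C@H]2NC(=O)c1cc2sc(Br)cc2n1Cc1ccc(OC)cc1`: > 100000 nM

Compound 3 reads > 100000 nM, which is a limit of the assay and not a number. Compound 4 `CCCNC(=O)[C@@H]1C[C@H]2CCC[C@@H](C1)[C@@H]2NC(=O)c1cc2sc(Br)cc2n1Cc1ccc(OC)cc1` is built from the same pieces as compound 3, and the change is this: the two compounds have the same atoms and bonds and differ only in configuration as drawn: 1 of 4 stereo elements differ; a stereocentre at a saturated ring carbon is drawn r in compound 3 and s in compound 4. Among the measured compounds shown here, no measured pair here shows what such a change of configuration does in this assay, so the expectation rests on compound 3 alone, and no step beyond the scatter is expected. The estimated at least 1.1-fold lower number from compound 3 to compound 4 (0.04 log units; that floor lies within the scatter) is therefore small. Compound 4 is estimated at 90000 nM, with an expected range of 35000 nM to 150000 nM.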

Compound 4, half-maximal cytotoxic concentration: > 100000 nM
Compound 4 was reported as a limit (the forecaster's own chance of this, stated with the estimate: 60%); middle value at least 1.1-fold (0.04 log units) away from the limit.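

No step can be read between compound 3 and compound 4, because both values are limits of the assay and not numbers: the limit of > 100000 nM in this assay, at which 2 of the 4 values shown sit.

As far as these compounds go, whether the configuration at that saturated ring carbon shifts the half-maximal cytotoxic concentration at all remains open.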